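Working notes: from compound 3 to compound 4

The source may hold more compounds than are shown below. What is called first, only, known or untested is meant among the compounds shown, and "the series" means these compounds.

The three measured compounds share one core. Compound 1 `Nc1nc2ccc(I)cc2s1` gives in a functional assay on the whole organism with Rattus norvegicus as the target (on this read-out higher numbers stand for an effect only at larger amounts of compound and lower numbers for an effect already at smaller amounts), only a limit, > 10 mg/kg. Compound 2 `Nc1nc2ccc(SC(F)(F)F)cc2s1` gives in this assay 8 mg/kg. Between them stands the one measured step, an at least 1.2-fold lower number from compound 1 to compound 2 (0.09 log units; that floor lies within the scatter), with (trifluoromethyl)sulfanyl in place of iodo on an aromatic carbon. Compound 3 `N=c1sc2cc(OC(F)(F)F)ccc2n1Cc1ccccc1` is recorded in this assay only as a limit, > 10 mg/kg. Where compound 3 stands among the numbers is thus open on one side; two of the three values sit at the same limit (the limit of > 10 mg/kg in this assay, at which 2 of the 3 values shown sit).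

Compound 4 `CCCSCCn1c(=N)sc2cc(OC(F)(F)F)ccc21` differs from compound 3 at the chain bound to the aromatic nitrogen: (propylsulfanyl)methyl in place of phenyl on a saturated chain carbon bound to an aromatic nitrogen. Among the compounds with values here, the one measured step, from compound 1 to compound 2, concerns a substituent on an aromatic carbon and not the chain on the aromatic nitrogen, so it does not bear on this change; no measured pair shows how a change at this place moves this assay. With compound 3 known only as a limit, the size of the step cannot be read from the numbers shown, and no move beyond the scatter in either direction is expected. Compound 4 is expected in this assay at about 12 mg/kg, between 4 mg/kg and 40 mg/kg, with a fair chance that again only a limit is recorded. The expected step is a step that the limit leaves unreadable from compound 3 to compound 4.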

Compound 4, dose for half-maximal effect: 2.4 mg/kg
For compound 4 the middle estimate is 5.0-fold (0.70 log units) above the measured one; the measured number lies below the stated range.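

At the chain on the aromatic nitrogen, this assay does respond: the change from benzyl to 2-(propylsulfanyl)ethyl gives an at least 4.1-fold lower number from compound 3 to compound 4 (0.61 log units; beyond the scatter) and is the first step shown at this place. In this pair, an aromatic ring on the chain is not needed for a measured value, since compound 4, whose chain has no ring, gives 2.4 mg/kg as a number. The step remains a floor and not a size because compound 3 is recorded only as a limit, which is shared with compound 1: the limit of > 10 mg/kg in this assay, at which 2 of the 4 values shown sit.

The compounds shown do not separate the part played by the sulfur from that of the lost ring or the chain length, which a hexyl chain, a longer chain, an ether oxygen in place of the sulfur or a terminal amine at this place would address. On these data alone, it also stays open whether 2-(propylsulfanyl)ethyl would move the read-out in the same way with (trifluoromethyl)sulfanyl on the aromatic carbon, as in compound 2.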